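The source may hold more compounds than are shown below. What is called first, only, known or untested is meant among the compounds shown, and "the series" means these compounds.

Measured compounds:
Compound 1 `Cc1cc(C2=C(c3ccccc3)CC3CCC2S3)on1`; in an assay for displacement of a labelled ligand from sodium-dependent dopamine transporter (Homo sapiens) (on this read-out higher numbers stand for weaker inhibition and lower numbers for stronger inhibition), compound 1 gives > 2000 nM, which is a limit of the assay and not a number.
Compound 2 `Cc1cc(C2=C(c3ccc(Cl)cc3)CC3CCC2S3)on1`; in this assay compound 2 gives 155 nM.

Compound 2 stands on the only number shown in this assay; the other value shown is a limit. The measured step of an at least 12-fold lower number from compound 1 to compound 2 (1.11 log units; beyond the scatter) is large and beyond the scatter, and it starts from the limit (the limit of > 2000 nM in this assay, at which 1 of the 2 values shown sits).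

Compound 3 `Cc1cc(C2=C(c3ccc(Br)cc3)CC3CCC2S3)on1` differs from compound 2 by bromo in place of chloro on an aromatic carbon. No measured step exchanges one halogen for another; the only step shown, hydrogen to chloro, bears on compound 3 just in that a halogen is kept on the same aromatic carbon, and it gives no size for a chloro-to-bromo exchange. With nothing to set a size, the change is expected to stay within the scatter in this assay, with no direction claimed. The expected step is a 1.3-fold lower number from compound 2 to compound 3 (0.11 log units; within the scatter). Compound 3 is estimated at 120 nM in this assay, with a range from 45 nM to 350 nM.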

Compound 3, half-maximal inhibitory concentration: 139 nM
Compound 3: middle estimate off by 1.2-fold (0.06 log units), on the low side, within the range that was stated.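

In this assay, bromo in place of chloro on the same aromatic carbon, para to a large group, gives a 1.1-fold lower number from compound 2 to compound 3 (0.05 log units; within the scatter), so the two halogens are not told apart at this position. The gain first seen with chloro now appears with a second halogen, which makes it more than a result for a single compound: an at least 14-fold lower number from compound 1 to compound 3 (1.15 log units; beyond the scatter). The full size of that step cannot be read, as compound 1 stands on a limit of the assay and not a number: the limit of > 2000 nM in this assay, at which 1 of the 3 values shown sits.

The compounds shown leave open whether the gain belongs to halogens alone or extends to other groups on this carbon, such as fluoro, methyl, methoxy, trifluoromethyl or an amine. Also open, going by these compounds, is whether chloro or bromo on another carbon of the same aromatic ring would give a step of similar size, and whether a second halogen on this ring would change the number further.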